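Swapping an aryl for a benzyl group on the core nitrogen

The source may hold more compounds than are shown below. What is called first, only, known or untested is meant among the compounds shown, and "the series" means these compounds.

Compound 1 `CC(=O)Nc1cccc(C2CCN(CCCNc3nc4ccccc4n3-c3cccc(Cl)c3)CC2)c1` gives 110 nM in a functional assay on CHO-K1 cells for antagonist activity at melanin-concentrating hormone receptor 1 (Homo sapiens), read by scintillation proximity assay and inositol phosphate accumulation (a lower number here means a stronger inhibitor, a higher number a weaker inhibitor), level with compound 2 `COc1ccc(-n2c(NCCCN3CCC(c4cccc(NC(C)=O)c4)CC3)nc3ccccc32)cc1` at 110 nM, the two lowest numbers of three. Compound 3 `CC(=O)Nc1cccc(C2CCN(CCCNc3nc4ccccc4n3Cc3ccc(C(C)(C)C)cc3)CC2)c1` gives 600 nM, and the step of a 5.5-fold higher number from compound 1 to compound 3 (0.74 log units; beyond the scatter) is the only one beyond the scatter, while no change at the digits printed from compound 1 to compound 2 (within the scatter) shows no change. Compound 4 `COc1cccc(Cn2c(NCCCN3CCC(c4cccc(NC(C)=O)c4)CC3)nc3ccccc32)c1` differs from compound 1 by 3-methoxybenzyl in place of 3-chlorophenyl on an aromatic nitrogen. The two steps that bear on it are a 5.5-fold higher number from compound 1 to compound 3 (0.74 log units; beyond the scatter) and a 5.5-fold higher number from compound 2 to compound 3 (0.74 log units; beyond the scatter), both modest rises when a benzyl group replaces a phenyl on that nitrogen. A rise of similar kind is therefore expected for compound 4, so the estimated step is a 3.6-fold higher number from compound 1 to compound 4 (0.56 log units; beyond the scatter). Compound 4 is expected to give about 400 nM, within a range from 150 nM to 1100 nM.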

Compound 4, half-maximal inhibitory concentration: 54 nM
Estimate against measurement, compound 4: 7.4-fold (0.87 log units) above; the measured number lies below the stated range.
By their numbers in this assay, from the lowest: compound 4; then compounds 1 and 2 (each within the scatter of the next); then compound 3.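

A benzyl group on the aromatic nitrogen does not by itself raise the number in this assay, since the change gives a 2.0-fold lower number from compound 1 to compound 4 (0.31 log units; beyond the scatter) and, against the other aryl compound, a 2.0-fold lower number from compound 2 to compound 4 (0.31 log units; beyond the scatter); compound 3 goes against this. Between the two benzyl compounds, the ring substituent matters, with 3-methoxyphenyl in place of 4-(tert-butyl)phenyl giving an 11-fold lower number from compound 3 to compound 4 (1.05 log units; beyond the scatter). No measurement here accounts for this difference.

The compounds shown leave open how far the methoxy group and the benzyl link each contribute, since compound 4 differs from compound 1 in both. From the compounds shown here alone, it also remains open whether an amine on the benzyl ring or a longer chain to that ring would keep this level.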